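A few compounds are considered here, and "the series" means these few. Any claim that something is new, unique, unknown or untested is made for them only; others in the source may bear on it.

Three compounds built on a shared core are considered here: compound 1 (`COc1ccc(/C=C/C(=O)c2cccc(Br)c2)cc1OC`), compound 2 (`COc1ccc(/C=C/C(=O)c2cccc(-c3cccc(F)c3)c2)cc1`) and compound 3 (`COc1ccc(/C=C/C(=O)c2cccc(-c3cccc(F)c3)c2)cc1OC`). For the measured compounds named here, in a functional assay on CNE-2 cells (Homo sapiens) for cytotoxicity, read by sulforhodamine B assay, with a stated time of 48 h (on this read-out higher numbers stand for weaker inhibition and lower numbers for stronger inhibition), compound 2 gives 740 nM as the only number so far, so it cannot yet be ranked against any neighbour. In this assay compound 1 has the entry "not determined" (no result reported) and offers no comparison, although it also carries the extra methoxy.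

Compound 3 differs from compound 2 in one place (methoxy in place of hydrogen on an aromatic carbon). In short, this is methoxy in place of hydrogen on an aromatic carbon, ortho to a methoxy group. Going by the values given here, no pair of measured compounds shows what such a change does in this assay, so any forecast has to stay cautious. With compound 2 at 740 nM as the sole anchor, the expectation is no step beyond the usual scatter, with only a slight lean towards stronger inhibition. The estimate amounts to a 1.1-fold lower number from compound 2 to compound 3 (0.06 log units; within the scatter) as the expected step, and it is a loose one. Compound 3 is expected at about 650 nM in this test, with an estimated range from 200 nM to 2200 nM for its result.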

Compound 3, half-maximal inhibitory concentration: 770 nM
Beside the measured number, compound 3's estimate is 1.2-fold (0.07 log units) below it; the measured number falls inside the stated range.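

In this assay, for the compounds shown here, the first measured pair for this change, methoxy in place of hydrogen on an aromatic carbon, ortho to a methoxy group, gives a 1.0-fold higher number from compound 2 to compound 3 (0.02 log units; within the scatter). Compound 2 and compound 3 therefore read alike, which shows that, at least with this core and this meta large group, the position can carry a methoxy group with its 2 heavy atoms without any step beyond the usual scatter of this kind of measurement. Nothing available here speaks to why the two compounds read alike.

The compounds shown leave open whether a longer chain such as butoxy at this position, or a group of a different kind such as an amine or a carboxylic acid, would also leave the number within the scatter. On these data alone, compound 1 also carries the extra methoxy but offers no number for comparison, so this reading rests on a single pair, and whether it holds when other parts of the molecule differ remains open.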